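Swapping the hydrazone aryl group: from hydroxyphenyl to dichlorophenyl

This account rests on a few compounds, and the source may have more. Where it says the series, first, only, none or still open, it means among the compounds named here.

Measured compounds:
- compound 1, `O=C(Cc1csc2nc(-c3ccc(Br)cc3)cn12)N/N=C/c1ccccc1O`: 17800 nM
- compound 2, `O=C(Cc1csc2nc(-c3ccc(Br)cc3)cn12)N/N=C/c1ccc(O)cc1`: 89100 nM
- compound 3, `COc1cccc(OC)c1/C=N/NC(=O)Cc1csc2nc(-c3ccc(Br)cc3)cn12`: > 100000 nM

Three hydrazones sharing the core of compound 1 have been tested in a functional assay (786-0 cells, Homo sapiens) for inhibition, read by sulforhodamine B assay, with a stated time of 48 h; a higher number here means a weaker inhibitor of growth, a lower number a stronger inhibitor of growth. Compound 1 gives the lowest of the two numbers recorded, and compound 2 stands nearest to it, the change being a 5.0-fold higher number from compound 1 to compound 2 (0.70 log units; beyond the scatter). Compound 3 reached only the limit of this assay, (the limit of > 100000 nM in this assay, at which 1 of the 3 values shown sits), and so no number is known for it; the move from compound 1 to compound 3 is therefore an at least 5.6-fold higher number from compound 1 to compound 3 (0.74 log units; beyond the scatter), and from compound 2 to compound 3 an at least 1.1-fold higher number from compound 2 to compound 3 (0.05 log units; that floor lies within the scatter).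

Compound 4, `O=C(Cc1csc2nc(-c3ccc(Br)cc3)cn12)N/N=C/c1ccc(Cl)cc1Cl`, differs from compound 1 in one place: 2,4-dichlorophenyl in place of 2-hydroxyphenyl on a carbon with a double bond to nitrogen. Both measured steps away from compound 1 went toward weaker growth inhibition, and both removed or moved the hydroxyl that sits on the 2-hydroxyphenyl ring. The entering 2,4-dichlorophenyl carries no hydroxyl at all, so compound 4 is expected to follow the same direction, with a step of a 2.8-fold higher number from compound 1 to compound 4 (0.45 log units; beyond the scatter) in this assay. Compound 4 is thus estimated at 50000 nM, with a range from 15000 nM to 100000 nM.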

Compound 4, concentration for total growth inhibition: 74100 nM
Estimate against measurement, compound 4: 1.5-fold (0.17 log units) below; measured number inside the range.
By their numbers in this assay, from the lowest: compound 1; then compounds 4 and 2 (each within the scatter of the next). At a limit, above all of these: compound 3.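

In this assay, 2,4-dichlorophenyl on the carbon with a double bond to nitrogen gives a 4.2-fold higher number from compound 1 to compound 4 (0.62 log units; beyond the scatter), so a ring with chlorine and no hydroxyl also falls short of compound 1. The step of a 1.2-fold lower number from compound 2 to compound 4 (0.08 log units; within the scatter) puts the hydroxyl-bearing 4-hydroxyphenyl and the hydroxyl-free 2,4-dichlorophenyl level, which means that having a hydroxyl on the ring does not by itself set these two apart, and among the measured numbers only the 2-hydroxyphenyl of compound 1 stands out. The remaining step, an at least 1.3-fold lower number from compound 3 to compound 4 (0.13 log units; that floor lies within the scatter), rests on a limit and settles no order: the limit of > 100000 nM in this assay, at which 1 of the 4 values shown sits.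

The compounds shown leave open whether compound 1 owes its lower number to the hydroxyl itself or to the rest of its ring pattern. Going by these compounds, how an unsubstituted phenyl or an aminophenyl group would read at this place also remains open.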